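Chloro in place of cyano: a small step expected

The source may hold more compounds than are shown below. What is called first, only, known or untested is meant among the compounds shown, and "the series" means these compounds.

Among the measured compounds shown here, in a functional assay (aorta) with Oryctolagus cuniculus as the target (a lower number here means tighter binding, a higher number weaker binding), compound 2 `N#Cc1ccc(OCCCN2CCC(C(c3ccc(F)cc3)c3ccc(F)cc3)CC2)cc1` gives 5.01 nM, the higher of the two numbers so far, while compound 1 `COC(=O)c1ccc(OCCCN2CCC(C(c3ccc(F)cc3)c3ccc(F)cc3)CC2)c(OC)c1` gives 1.26 nM. Compound 3 `Fc1ccc(C(c2ccc(F)cc2)C2CCN(CCCOc3ccc(Cl)cc3)CC2)cc1` keeps the shared core but carries chloro in place of cyano on an aromatic carbon, para to a large group: chloro in place of cyano on an aromatic carbon. For the measured compounds named here, the one measured step that bears on this, a 4.0-fold higher number from compound 1 to compound 2 (0.60 log units; beyond the scatter), was modest and replaced a larger group. The expected change in this assay is therefore small, a 1.3-fold lower number from compound 2 to compound 3 (0.10 log units; within the scatter), with none expected beyond the scatter. Compound 3 is estimated at 4 nM, within a range from 1.5 nM to 12 nM.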

Compound 3, dissociation constant: 2 nM
The estimate for compound 3 lay 2.0-fold (0.30 log units) above the measured number; the range from low to high includes it.
By their numbers in this assay, from the lowest: compounds 1 and 3 (each within the scatter of the next); then compound 2.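

In this assay, the swap on this aromatic carbon, para to a large group, is not silent: chloro in place of cyano gives a 2.5-fold lower number from compound 2 to compound 3 (0.40 log units; beyond the scatter). The 4-chlorophenyl group and the larger 2-methoxy-4-(methoxycarbonyl)phenyl group cannot be told apart here, with a 1.6-fold higher number from compound 1 to compound 3 (0.20 log units; within the scatter). Nothing measured here explains the difference between cyano and chloro.

Going by these compounds, it remains open how an amine or a carboxylic acid at this position would compare. Also open, on these data alone, is whether chloro and cyano would differ in the same way on a longer chain.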